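The compounds below may be only part of what the source reports. "The series", "measured", "known", "first", "only" and "open" are said of these compounds alone.

Working notes on a small ester series built on one shared core.

Compound 1 `CC1=CC[C@H]2[C@H](CC[C@]2(C)O)C(C)(C)[C@@H]1CC[C@H]1[C@]2(C)CC[C@H](OC(=O)c3ccc(F)cc3)C(C)(C)O[C@H]2CC[C@@]1(C)O` carries the (4-fluorophenyl)carbonyl ester; in a functional assay on MDA-MB-231 cells (Homo sapiens) for antiproliferative activity, read by MTT assay, with a stated time of 72 h (on this read-out lower numbers stand for stronger inhibition and higher numbers for weaker inhibition), compound 1 gives 11300 nM. Compound 2 `CC1=CC[C@H]2[C@H](CC[C@]2(C)O)C(C)(C)[C@@H]1CC[C@H]1[C@]2(C)CC[C@H](OC(=O)c3ccc(C(F)(F)F)cc3)C(C)(C)O[C@H]2CC[C@@]1(C)O` differs from compound 1 by trifluoromethyl in place of fluoro on an aromatic carbon; in this assay compound 2 gives 19500 nM, a step of a 1.7-fold higher number from compound 1 to compound 2 (0.24 log units; within the scatter). Compound 3 `CC1=CC[C@H]2[C@H](CC[C@]2(C)O)C(C)(C)[C@@H]1CC[C@H]1[C@]2(C)CC[C@H](OC(=O)c3ccccc3F)C(C)(C)O[C@H]2CC[C@@]1(C)O` differs from compound 1 by 2-fluorophenyl in place of 4-fluorophenyl on a carbonyl carbon; in this assay compound 3 gives 28700 nM, with steps of a 2.5-fold higher number from compound 1 to compound 3 (0.40 log units; beyond the scatter) and a 1.5-fold higher number from compound 2 to compound 3 (0.17 log units; within the scatter).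

Compound 4 `CC1=CC[C@H]2[C@H](CC[C@]2(C)O)C(C)(C)[C@@H]1CC[C@H]1[C@]2(C)CC[C@H](OC(=O)c3ccccc3C(F)(F)F)C(C)(C)O[C@H]2CC[C@@]1(C)O` is not yet measured; it differs from compound 3 by trifluoromethyl in place of fluoro on an aromatic carbon. This is the same kind of change as that from compound 1 to compound 2, but not the same: there the group sits para to a large group, here ortho to a large group. The step expected here is a 1.6-fold higher number from compound 3 to compound 4 (0.20 log units; within the scatter), resting on a 1.7-fold higher number from compound 1 to compound 2 (0.24 log units; within the scatter). Compound 4 is expected to give about 45000 nM in this assay, estimated between 20000 nM and 100000 nM.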

Compound 4, half-maximal inhibitory concentration: 31500 nM
The estimate for compound 4 lay 1.4-fold (0.15 log units) above the measured number; measured number inside the range.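

In this assay, trifluoromethyl in place of fluoro gives a 1.1-fold higher number from compound 3 to compound 4 (0.04 log units; within the scatter), and this step agrees with the earlier one: the same change on two cores in this assay, a 1.7-fold higher number (0.24 log units; within the scatter) from compound 1 to compound 2 and a 1.1-fold higher number (0.04 log units; within the scatter) from compound 3 to compound 4, 1.6-fold (0.20 log units) apart, within the scatter of two such steps. The change therefore carries across these two settings without a detectable difference, but neither step lies beyond the scatter, so two pairs in one assay show no real effect of the change and say nothing about other cores. Of the remaining steps, a 1.6-fold higher number from compound 2 to compound 4 (0.21 log units; within the scatter) is also within the scatter, while a 2.8-fold higher number from compound 1 to compound 4 (0.45 log units; beyond the scatter) is beyond it, though that pair differs in both the group and its place on the ring.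

Open, on these data alone, is whether an amine or a carboxylic acid on the same aromatic ring would give a step beyond the scatter.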